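The compounds below may be only part of what the source reports. "The series", "measured", "known", "first", "only" and "open" are said of these compounds alone.

Values in a functional assay on MDA-MB-231 cells (Homo sapiens) for antiproliferative activity, read by sulforhodamine B assay, with a stated time of 48 h; on this read-out higher numbers stand for weaker inhibition and lower numbers for stronger inhibition:
compound 1 `Cc1cccc(NS(=O)(=O)c2ccc(N3CCNC3=O)cc2)c1`: 1270 nM
compound 2 `CCc1cccc(NS(=O)(=O)c2ccc(N3CCNC3=O)cc2)c1`: 1410 nM
compound 3 `Cc1cc(C)cc(NS(=O)(=O)c2ccc(N3CCNC3=O)cc2)c1`: 1220 nM

All three compounds share one core and differ only in the aryl group on the sulfonamide nitrogen. On these numbers, compound 3 cannot be separated from the other two: the steps are a 1.0-fold lower number from compound 1 to compound 3 (0.02 log units; within the scatter) and a 1.2-fold lower number from compound 2 to compound 3 (0.06 log units; within the scatter). The remaining step, a 1.1-fold higher number from compound 1 to compound 2 (0.05 log units; within the scatter), is also within the scatter.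

The next compound, compound 4 `O=C1NCCN1c1ccc(S(=O)(=O)Nc2cccc(Cl)c2)cc1`, carries 3-chlorophenyl in place of 3,5-dimethylphenyl on a sulfonamide nitrogen. Among the compounds with values here, no compound with chlorine has been measured, so no step bears on this swap directly. The nearest evidence is the three small steps above, all among alkyl-substituted phenyl groups, and that makes the expectation an indirect one. No step beyond the scatter is therefore expected, in either direction. The estimated step is a 1.1-fold higher number from compound 3 to compound 4 (0.03 log units; within the scatter). For compound 4 the expected value is 1300 nM, with an estimated range from 650 nM to 2600 nM.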

Compound 4, half-maximal inhibitory concentration: 200 nM
Beside the measured number, compound 4's estimate is 6.5-fold (0.81 log units) above it, and the stated range ends above it.
By their numbers in this assay, from the lowest: compound 4; then compounds 3, 1 and 2 (each within the scatter of the next).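

Among the aryl groups on the sulfonamide nitrogen, the alkyl-substituted ones had stayed within the scatter of each other in this assay, but this position does respond to a change of substituent: chloro in place of methyl on an aromatic carbon gives a 6.4-fold lower number from compound 1 to compound 4 (0.80 log units; beyond the scatter), and chloro in place of ethyl gives a 7.1-fold lower number from compound 2 to compound 4 (0.85 log units; beyond the scatter). Replacing 3,5-dimethylphenyl with 3-chlorophenyl gives a similar change, a 6.1-fold lower number from compound 3 to compound 4 (0.79 log units; beyond the scatter), so all three alkyl-substituted compounds stand apart from the chloro compound by about the same margin. Nothing measured here bears on why this substitution matters.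

Compound 4 is the only compound shown that carries chlorine, so a single value stands behind this change. Going by these compounds, whether bromine or fluorine in place of that chlorine would do the same, or how an amine or a carboxylic acid on that phenyl ring would fare, remains open.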